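Cyano for methyl on the benzyl ether of compound 2

This account rests on a few compounds, and the source may have more. Where it says the series, first, only, none or still open, it means among the compounds named here.

Compound 1 `CN1CCN(CCCCOc2c(OCc3ccccc3)cc(O)c3c(=O)cc(-c4ccccc4)oc23)CC1` and compound 2 `Cc1ccc(COc2cc(O)c3c(=O)cc(-c4ccccc4)oc3c2OCCCCN2CCN(C)CC2)cc1` share one core and differ by methyl in place of hydrogen on an aromatic carbon. In a functional assay on A549 cells (Homo sapiens) for cytotoxicity, read by MTT assay, with a stated time of 72 h (a lower number here means a stronger inhibitor, a higher number a weaker inhibitor), compound 1 gives 2910 nM and compound 2 gives 3200 nM. The step of a 1.1-fold higher number from compound 1 to compound 2 (0.04 log units; within the scatter) shows no change beyond the scatter, so compound 2 holds the higher of the two numbers only nominally; the two compounds sit together.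

Compound 3 `CN1CCN(CCCCOc2c(OCc3ccc(C#N)cc3)cc(O)c3c(=O)cc(-c4ccccc4)oc23)CC1` is not yet measured. It differs from compound 2 by cyano in place of methyl on an aromatic carbon. For the measured compounds named here, no measured step covers cyano entering at this place. Going by the values given here, the only step, a 1.1-fold higher number from compound 1 to compound 2 (0.04 log units; within the scatter), concerns methyl against hydrogen on an aromatic carbon and lies within the scatter, which gives no ground to expect a shift beyond the scatter in this assay in either direction; the range is set wide for lack of a direct comparison.

Compound 3 is therefore expected to give about 3200 nM, with a range of 1300 nM to 8000 nM. The expected step is no change at the digits printed from compound 2 to compound 3 (within the scatter), within the scatter.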

Compound 3, half-maximal inhibitory concentration: 2140 nM
Beside the measured number, compound 3's estimate is 1.5-fold (0.17 log units) above it, within the range that was stated.
By their numbers in this assay, from the lowest: compounds 3, 1 and 2 (each within the scatter of the next).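

In this assay the exchange of 4-methylbenzyl for 4-cyanobenzyl gives a 1.5-fold lower number from compound 2 to compound 3 (0.17 log units; within the scatter) and the comparison with the plain benzyl ether gives a 1.4-fold lower number from compound 1 to compound 3 (0.13 log units; within the scatter), so both new steps lie within the scatter. The earlier compounds shown here covered only hydrogen and methyl at this place, on an aromatic carbon para to a large group; hydrogen, methyl and cyano now all read together, and the entry of a nitrile with its one hydrogen-bond acceptor brings no step beyond the scatter. No measurement is available here that bears on why these three compounds sit together.

The compounds shown leave open whether any group at this place gives a step beyond the scatter, for instance a carboxylic acid, an amine or a longer chain in place of cyano. They also leave open whether cyano reads the same way on another carbon of the same ring, and whether a change elsewhere on the shared core would separate these compounds in this cytotoxicity read-out.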